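The source may hold more compounds than are shown below. What is called first, only, known or untested is meant among the compounds shown, and "the series" means these compounds.

Measured in a functional assay on CHO-K1 cells with Glucose-dependent insulinotropic receptor (Homo sapiens) as the target, read by a luciferase reporter, with a stated time of 5 h; a lower number here means a smaller maximal response, a higher number a larger maximal response:
compound 1, `CC(C)OC(=O)N1CCC(Oc2ncnc3c2CCN3c2ccc(S(C)(=O)=O)cc2F)CC1`: 91%
compound 2, `CCOC(=O)N1CCC(Oc2ncnc3c2CCN3c2ccc(S(C)(=O)=O)cc2F)CC1`: 135%
compound 3, `CCCOC(=O)N1CCC(Oc2ncnc3c2CCN3c2ccc(S(C)(=O)=O)cc2F)CC1`: 111%

Compound 3 stands second highest of the three in this assay. Its nearest neighbour is compound 1, with a number 20 percentage points higher from compound 1 to compound 3 (beyond the scatter); its furthest is compound 2, with a number 24 percentage points lower from compound 2 to compound 3 (beyond the scatter); both steps lie beyond the scatter.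

Compound 4 is `CC(C)COC(=O)N1CCC(Oc2ncnc3c2CCN3c2ccc(S(C)(=O)=O)cc2F)CC1`. Against compound 3 the difference is methyl in place of hydrogen on a saturated chain carbon bound to two saturated chain carbons; cut one bond further out it reads propyl to isobutyl.

Among the compounds with values here, two measured steps bear on this. Removing the methyl from the chain carbon bound to the oxygen gave a number 44 percentage points higher from compound 1 to compound 2 (beyond the scatter), a large rise. Adding a methyl two bonds along the chain from that oxygen gave a number 24 percentage points lower from compound 2 to compound 3 (beyond the scatter), a modest fall. Both point the same way: a methyl entering the chain lowers the maximal response, and the fall is smaller where the methyl sits one bond further out. The methyl entering in compound 4 sits further out again, so a small drop, possibly within the scatter, is expected.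

Compound 4 is therefore expected at 100% (range 78% to 125%), an expected step of a number 11 percentage points lower from compound 3 to compound 4 (beyond the scatter).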

Compound 4, largest response reached (reported as percent of maximum), in percent of the reference or control that the assay uses: 94%
Compound 4: middle estimate off by 6 percentage points, on the high side, within the range that was stated.
By their numbers in this assay, from the lowest: compounds 1 and 4 (each within the scatter of the next); then compound 3; then compound 2.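

In this assay, a methyl entering this far out still lowers the maximal response: methyl in place of hydrogen on a saturated chain carbon bound to two saturated chain carbons gives a number 17 percentage points lower from compound 3 to compound 4 (beyond the scatter), so propyl to isobutyl is not a silent change. Branching also outweighs the extra carbon count, as isobutyl in place of isopropyl gives a number 3 percentage points higher from compound 1 to compound 4 (within the scatter), while isopropyl in place of methyl on the chain carbon bound to the oxygen gives a number 41 percentage points lower from compound 2 to compound 4 (beyond the scatter), so both branched chains lie well short of the ethyl of compound 2. A methyl step at this end of the molecule has no fixed size: the same change on two cores in this assay, a number 44 percentage points higher (beyond the scatter) from compound 1 to compound 2 and a number 17 percentage points higher (beyond the scatter) from compound 4 to compound 3, 27 percentage points apart, beyond the scatter of two such steps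

Going by these compounds, whether the response rises further with a single methyl on the oxygen remains open. So does the outcome with a longer chain such as butyl or a ring such as cyclopropyl.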